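Methylating the Methylamino Group on the Shared Core

A few compounds are considered here, and "the series" means these few. Any claim that something is new, unique, unknown or untested is made for them only; others in the source may bear on it.

The study concerns three measured compounds and one awaiting measurement. In a functional assay (Oryctolagus cuniculus) for inhibition (a higher number here means a weaker inhibitor, a lower number a stronger inhibitor), compound 1 `Nc1nc2c(nc(Cl)n2COCCO)c(=O)[nH]1` gives a limit rather than a number, > 400 ug/mL. Compound 2 `Nc1nc2c(nc(Br)n2COCCO)c(=O)[nH]1` gives 340 ug/mL in this assay. Compound 3 `CNc1nc2c(=O)[nH]c(N)nc2n1COCCO` again gives only a limit, > 400 ug/mL, in this assay. The step of an at least 1.1-fold lower number from compound 1 to compound 2 (0.07 log units; that floor lies within the scatter) lies within the scatter, the step of an at least 1.1-fold higher number from compound 2 to compound 3 (0.07 log units; that floor lies within the scatter) likewise, and the step that the two limits leave unreadable from compound 1 to compound 3 runs between two limits. Compound 3 thus sits at the limit of > 400 ug/mL in this assay, at which 2 of the 3 values shown sit. Compound 4 `CN(C)c1nc2c(=O)[nH]c(N)nc2n1COCCO` differs by methyl in place of hydrogen on a nitrogen on an aromatic ring. Going by the values given here, no measured step alters the nitrogen on an aromatic ring, so compound 4 is expected to show only a step that the limit leaves unreadable from compound 3 to compound 4, an expectation of no shift past the scatter. Compound 4 is therefore expected to give 500 ug/mL in this assay, within 250 ug/mL to 1000 ug/mL.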

Compound 4, concentration for 50% inhibition: > 400 ug/mL
Compound 4: a limit, no number; the forecaster's own chance of this, stated with the estimate: 70%; the middle value does not contradict the limit.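

In this assay, dimethylamino in place of methylamino still returns a limit, so the steps from compound 3 and from compound 1 to compound 4 cannot be read. Dimethylamino in place of bromo gives an at least 1.1-fold higher number from compound 2 to compound 4 (0.07 log units; that floor lies within the scatter), which shows no change past the scatter. The second methyl on this nitrogen therefore brings no readable number, and the set gathers further at one limit: the limit of > 400 ug/mL in this assay, at which 3 of the 4 values shown sit.

From the compounds shown here alone, whether compound 3 and compound 4 differ at all stays open. So does whether a plain amino group, an ethylamino chain or a carboxylic acid on that aromatic carbon would give a number rather than a limit.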